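The source may report more compounds than this note shows. Statements on the series, on what has been measured and on what is new or still open speak of the compounds shown alone.

Three compounds that share one core were examined in an ADME assay on MDCK cells (Canis lupus familiaris) for cytotoxicity, read by microscopy, with a stated time of 72 h; on this read-out higher numbers stand for lower toxicity in this test and lower numbers for higher toxicity in this test. Compound 1 `COC(=O)C[C@H](NC(=O)OC(C)(C)C)C(=O)N(Cc1ccccc1)C1(C(=O)NCc2ccccc2)CCN(Cc2ccccc2)CC1` carries a benzyl group on an amide-type nitrogen, and in this assay compound 1 reaches only a limit, > 100000 nM, which is a limit of the test rather than a number (the limit of > 100000 nM in this assay, at which 1 of the 3 values shown sits). Compound 3 `COC(=O)C[C@H](NC(=O)OC(C)(C)C)C(=O)NC1(C(=O)NCc2ccccc2)CCN(Cc2ccccc2)CC1` has hydrogen in that place, and in this assay compound 3 gives 100000 nM. The step of a number no higher from compound 1 to compound 3 (the limit leaves the size open) therefore cannot be sized. Compound 2 `COC(=O)C[C@H](NC(=O)OC(C)(C)C)C(=O)N(Cc1ccc(F)cc1)C1(C(=O)NC(C)(C)C)CCN(Cc2ccccc2)CC1` differs from compound 3 in two places. In this assay compound 2 gives 80000 nM. Of the two numbers available, compound 3 holds the higher one, but its gap to compound 2 lies within the scatter, so the two cannot be ordered.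

Compound 4 `CCC(C)N(C(=O)[C@H](CC(=O)OC)NC(=O)OC(C)(C)C)C1(C(=O)NCc2ccccc2)CCN(Cc2ccccc2)CC1` is the compound still to be measured. It differs from compound 3 by sec-butyl in place of hydrogen on an amide-type nitrogen. Going by the values given here, the one measured step on this amide-type nitrogen has no readable size, and compound 2, which also bears a substituent on that nitrogen, sits within the scatter of compound 3. The expected step is no change at the digits printed from compound 3 to compound 4 (within the scatter), nothing beyond the scatter. Compound 4 is therefore estimated at 100000 nM, with a range from 40000 nM to 200000 nM.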

Compound 4, minimum cytotoxic concentration: 84000 nM
Beside the measured number, compound 4's estimate is 1.2-fold (0.08 log units) above it; low and high end bracket the measured number.
By their numbers in this assay, from the lowest: compounds 2, 4 and 3 (each within the scatter of the next).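

In this assay, the amide-type nitrogen now has its first step of readable size: a 1.2-fold lower number from compound 3 to compound 4 (0.08 log units; within the scatter). Sec-butyl in place of hydrogen therefore adds 4 heavy atoms at this nitrogen without moving the number beyond the scatter, a statement that holds for this pair alone. Set against benzyl at the same place, the change gives an at least 1.1-fold lower number from compound 1 to compound 4 (0.07 log units; that floor lies within the scatter), and only a floor can be read, since compound 1 stands at a limit rather than a number: the limit of > 100000 nM in this assay, at which 1 of the 4 values shown sits.

The compounds shown leave open whether a different group on this nitrogen, such as a chain ending in an amine or a carboxylic acid, would shift the number beyond the scatter. Also open, from the compounds shown here alone, is whether the sec-butyl result carries over when other parts of the shared core change, as compound 2 differs from compound 3 in two places and so offers no single-change comparison.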